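The compounds below may be only part of what the source reports. "The series", "measured", "known", "first", "only" and "open" are said of these compounds alone.

Two entries in an assay on CHO cells for displacement of a labelled ligand from prostaglandin E2 receptor EP2 subtype (Mus musculus), read by scintillation counting, with a stated time of 60 min (on this read-out lower numbers stand for stronger inhibition and higher numbers for weaker inhibition), stand so far. Compound 1 `O=C(O)CCCSCCN1C(=O)CC[C@@H]1/C=C/[C@@H](O)Cc1cccc(OCc2ccncc2)c1` gives > 10000 nM, which is a limit of the assay rather than a number; (the limit of > 10000 nM in this assay, at which 1 of the 2 values shown sits). Compound 2 `O=C(O)c1csc(SCCN2C(=O)CC[C@@H]2/C=C/[C@@H](O)Cc2cccc(-c3ccc(Cl)cc3)c2)n1` gives 1.7 nM in this assay. Going by the values given here, compound 2 thus holds the only numeric value shown, the other entry being a limit, so no measured step between compounds can be drawn from this pair.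

Compound 3 `Cc1cc(C)c2oc(-c3cccc(C[C@H](O)/C=C/[C@H]4CCC(=O)N4CCSc4nc(C(=O)O)cs4)c3)nc2c1` has not yet been measured in this assay. It differs from compound 2 in one place: 5,7-dimethyl-1,3-benzoxazol-2-yl in place of 4-chlorophenyl on an aromatic carbon, meta to a large group. Among the compounds with values here, with no measured step available in the set, the size of this change has to be judged from the structural change alone, and there is no basis for a strong pull in either direction. The step from compound 2 to compound 3 is expected to be a 1.8-fold higher number from compound 2 to compound 3 (0.25 log units; within the scatter), within or close to the scatter. Compound 3 is therefore estimated at 3 nM, with a range from 0.5 nM to 20 nM.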

Compound 3, inhibition constant: 24 nM
Estimate against measurement, compound 3: 8.0-fold (0.90 log units) below, and the stated range ends below it.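

In this assay, going by these compounds alone, the aromatic carbon meta to a large group proves sensitive to what it carries: 5,7-dimethyl-1,3-benzoxazol-2-yl in place of 4-chlorophenyl gives a 14-fold higher number from compound 2 to compound 3 (1.15 log units; beyond the scatter), the first measured step. The change brings in more heavy atoms, a second ring and hydrogen-bond acceptors that 4-chlorophenyl lacks, and this single step cannot show which of these differences goes with the higher number, although compound 3 at 24 nM still gives a numeric value rather than a limit. Within the data shown here, nothing measured so far bears on why the number rises at this position.

A plain 1,3-benzoxazol-2-yl, without the two methyl groups, would separate the contribution of those methyls from that of the ring system as a whole. From the compounds shown here alone, whether a plain phenyl at the same carbon would read close to compound 2, and so show how much of its value depends on the chlorine, also remains open.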